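A few compounds are considered here, and "the series" means these few. Any claim that something is new, unique, unknown or untested is made for them only; others in the source may bear on it.

Series notes, urea-linked pyrazoline set. Compound 1 `O=C(Nc1ccc(F)cc1)N1N=C(c2ccc(Br)cc2)CC1c1ccc(F)cc1` gives 16 nM in an assay on HEK293 cells for inhibition of Voltage-dependent T-type calcium channel subunit alpha-1H (Homo sapiens), read by FLIPR and calcium flux, with a stated time of 3 min; on this read-out higher numbers stand for weaker inhibition and lower numbers for stronger inhibition. Going by the values given here, compound 2 `COc1ccc(NC(=O)N2N=C(c3ccc(Br)cc3)CC2c2ccc(F)cc2)cc1` gives 447 nM in this assay, the highest of the two numbers measured so far; its only neighbour is compound 1, and the step of a 28-fold higher number from compound 1 to compound 2 (1.45 log units; beyond the scatter) lies beyond the scatter.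

Compound 3 `O=C(NC1CCCCC1)N1N=C(c2ccc(Br)cc2)CC1c1ccc(F)cc1`, not yet measured in this assay, differs from compound 2 by cyclohexyl in place of 4-methoxyphenyl on an amide-type nitrogen. Among the compounds with values here, no measured step covers this exchange directly; the one available step, a 28-fold higher number from compound 1 to compound 2 (1.45 log units; beyond the scatter), concerns only the substituent on the phenyl ring that now leaves, and shows that this part of the urea is sensitive to change. Compound 2 sits at the weak end of that step, so a move away from the methoxy-bearing ring is expected to give a lower number rather than a higher one, though with wide uncertainty. For compound 3 the estimate is 150 nM, within 30 nM to 800 nM. The step implied, a 3.0-fold lower number from compound 2 to compound 3 (0.47 log units; beyond the scatter), is an expectation only.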

Compound 3, half-maximal inhibitory concentration: 316 nM
The estimate for compound 3 lay 2.1-fold (0.32 log units) below the measured number, and the stated range covers the measured number.
By their numbers in this assay, from the lowest: compound 1; then compounds 3 and 2 (each within the scatter of the next).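

Exchanging the whole ring on the amide-type nitrogen, with cyclohexyl in place of 4-methoxyphenyl, gives a 1.4-fold lower number from compound 2 to compound 3 (0.15 log units; within the scatter) in this assay and so does not separate these two compounds. Cyclohexyl in place of 4-fluorophenyl gives a 20-fold higher number from compound 1 to compound 3 (1.30 log units; beyond the scatter) and does not keep the low number of compound 1; since compound 2 also fails to keep it, an aromatic ring at this position is not sufficient in itself, and among these three compounds only 4-fluorophenyl gives a low number. No measurement at hand explains either step.

The compounds shown leave open whether the low number depends on the fluoro group itself or on the ring that carries it. Unsubstituted phenyl, 4-chlorophenyl and benzyl on this nitrogen would bear on that question.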